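This account rests on a few compounds, and the source may have more. Where it says the series, first, only, none or still open, it means among the compounds named here.

Notes on the shared core of compound 3 `CCOc1ccc(Br)cc1-c1cc(Nc2ccccc2)nc(N)n1`. Compound 1 `CCOc1ccc(Br)cc1-c1cc(Nc2ccc(C(=N)N)cc2)nc(N)n1` reaches only the limit > 5000 nM of an assay on Sf9 cells for inhibition of 1-acyl-sn-glycerol-3-phosphate acyltransferase beta (Homo sapiens) (on this read-out higher numbers stand for weaker inhibition and lower numbers for stronger inhibition), a limit rather than a number (the limit of > 5000 nM in this assay, at which 1 of the 3 values shown sits). Compound 2 `Cc1ccc(Br)cc1-c1cc(Nc2ccc(Cl)cc2)nc(N)n1` gives 31 nM in this assay, and compound 3 gives 120 nM. Within the measured numbers compound 3 stands highest, with compound 2 nearest and beyond the scatter. For the measured compounds named here, the one measured step, an at least 41-fold lower number from compound 1 to compound 3 (1.61 log units; beyond the scatter), concerns the amidine and not the change at hand. Compound 4 `CCOc1ccc(Br)cc1-c1cc(Nc2ccc(Cl)cc2)nc(N)n1` follows from compound 3 by chloro in place of hydrogen on an aromatic carbon. Going by the values given here, no measured step isolates this change; compound 2 and compound 3 differ in two places, so their values only show the chloro-bearing compound 2 sitting lower. A modest lowering is therefore expected, a 2.4-fold lower number from compound 3 to compound 4 (0.38 log units; beyond the scatter). Compound 4 is estimated at 50 nM, between 18 nM and 150 nM.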

Compound 4, half-maximal inhibitory concentration: 16 nM
Compound 4: the middle estimate sits 3.1-fold (0.49 log units) above what was measured, outside the stated range (below it).
By their numbers in this assay, from the lowest: compounds 4 and 2 (each within the scatter of the next); then compound 3. At a limit, above all of these: compound 1.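

In this assay, for the compounds shown here, the change from anilino to (4-chlorophenyl)amino gives a 7.5-fold lower number from compound 3 to compound 4 (0.88 log units; beyond the scatter), the first reading of chloro in place of hydrogen at this position with nothing else altered. With chloro present, ethoxy in place of methyl gives a 1.9-fold lower number from compound 2 to compound 4 (0.29 log units; within the scatter), so that swap shows no difference beyond the scatter. Chloro in place of the amidine gives an at least 310-fold lower number from compound 1 to compound 4 (2.49 log units; beyond the scatter), and this step rests on the limit of compound 1: the limit of > 5000 nM in this assay, at which 1 of the 4 values shown sits.

Going by these compounds, how fluoro, methoxy or a carboxylic acid would read at this position remains open. On these data alone, whether the ethoxy and methyl groups also match without the chloro remains open too.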